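The compounds below may be only part of what the source reports. "The series", "measured", "known", "first", "only" and "open" are said of these compounds alone.

Measured compounds:
Compound 1, `CC(C(=O)NCc1ccc(C(F)(F)F)cc1N1CCCC1)c1ccc(NS(C)(=O)=O)c(F)c1`, gives 2.3 nM in an assay on CHO cells for antagonist activity at transient receptor potential cation channel subfamily V member 1 (Homo sapiens), read by FLIPR; on this read-out higher numbers stand for weaker inhibition and lower numbers for stronger inhibition.
Compound 2, `COc1ccc(CSc2cc(C(F)(F)F)ccc2CNC(=O)C(C)c2ccc(NS(C)(=O)=O)c(F)c2)cc1`, gives 2.3 nM in this assay.
Compound 3, `CC(C(=O)NCc1ccc(C(F)(F)F)cc1-c1cccc(F)c1)c1ccc(NS(C)(=O)=O)c(F)c1`, gives 1.9 nM in this assay.

Compound 3 carries the lowest of these three numbers, but its gap to compound 1 and to compound 2 is within the scatter in each case, so the three compounds cannot be ordered on the numbers shown. All three vary only the group on one aromatic carbon of the shared core. The steps of a 1.2-fold lower number from compound 1 to compound 3 (0.08 log units; within the scatter) and a 1.2-fold lower number from compound 2 to compound 3 (0.08 log units; within the scatter) both bear on this position, and neither moved the number beyond the scatter despite exchanging groups of quite different kind.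

Compound 4, `CC(C(=O)NCc1ccc(C(F)(F)F)cc1-c1ccc(F)c(Cl)c1)c1ccc(NS(C)(=O)=O)c(F)c1`, continues this series: 3-chloro-4-fluorophenyl in place of 3-fluorophenyl on an aromatic carbon. The change is small, a chlorine added to a group that already sits at the same place. Given that larger exchanges at this position left this assay unchanged, the expected step of a 1.1-fold lower number from compound 3 to compound 4 (0.02 log units; within the scatter) is no change beyond the scatter. Compound 4 is therefore estimated at 1.8 nM, within a range from 0.8 nM to 4 nM.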

Compound 4, inhibition constant: 0.6 nM
Estimate against measurement, compound 4: 3.0-fold (0.48 log units) above; the measured number lies below the stated range.
By their numbers in this assay, from the lowest: compound 4; then compounds 3, 1 and 2 (each within the scatter of the next).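

Adding a chlorine to the 3-fluorophenyl group gave a 3.2-fold lower number from compound 3 to compound 4 (0.50 log units; beyond the scatter) in this assay, so this position is not as indifferent as compounds 1, 2 and 3 suggested, and a small change moved the number where larger exchanges had not. Compound 4 also separates from the other two compounds, with a 3.8-fold lower number from compound 2 to compound 4 (0.58 log units; beyond the scatter) and a 3.8-fold lower number from compound 1 to compound 4 (0.58 log units; beyond the scatter) for the exchanges of their groups, so all three steps lie beyond the scatter while remaining modest. Nothing available here explains why this added chlorine made a difference.

As far as these compounds go, whether a 3-chlorophenyl or a 4-fluorophenyl group at this place would read like compound 3 or like compound 4 stays open. Also open, from the compounds shown here alone, is how a phenyl ring carrying a nitrile or a second chlorine would compare with compound 4.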